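A few compounds are considered here, and "the series" means these few. Any claim that something is new, unique, unknown or untested is made for them only; others in the source may bear on it.

Measured compounds, with values in an assay on CHO cells for antagonist activity at transient receptor potential cation channel subfamily V member 1 (Homo sapiens), read by FLIPR and calcium flux; on this read-out higher numbers stand for weaker inhibition and lower numbers for stronger inhibition:
compound 1 `CC(C(=O)NCc1ccc(C(F)(F)F)nc1Br)c1ccc(NS(C)(=O)=O)c(F)c1`: 169 nM
compound 2 `CC(C(=O)NCc1ccc(C(F)(F)F)nc1C1CCC(F)(F)CC1)c1ccc(NS(C)(=O)=O)c(F)c1`: 1.5 nM
compound 3 `CC(C(=O)NCc1ccc(C(F)(F)F)nc1C1=CCC(C(C)(C)C)CC1)c1ccc(NS(C)(=O)=O)c(F)c1`: 0.2 nM

Compound 3 gives the lowest number of the three in this assay. The nearest measured compound is separated from it by a 7.5-fold lower number from compound 2 to compound 3 (0.88 log units; beyond the scatter), the furthest by an 850-fold lower number from compound 1 to compound 3 (2.93 log units; beyond the scatter).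

Compound 4 `CCC/C=C\c1nc(C(F)(F)F)ccc1CNC(=O)C(C)c1ccc(NS(C)(=O)=O)c(F)c1` is not yet measured. Its change from compound 3 is pent-1-en-1-yl in place of 4-(tert-butyl)cyclohex-1-en-1-yl on an aromatic carbon.

All three measured steps concern the same aromatic carbon. The steps of a 110-fold lower number from compound 1 to compound 2 (2.05 log units; beyond the scatter) and an 850-fold lower number from compound 1 to compound 3 (2.93 log units; beyond the scatter) show that a ring group in place of bromo lowers the number sharply; the step of a 7.5-fold lower number from compound 2 to compound 3 (0.88 log units; beyond the scatter) shows that the bulkier ring group lowers it further. Pent-1-en-1-yl has no ring and fewer heavy atoms than either ring group, yet far more than bromo. Within the data shown here, no measured step covers an acyclic chain at this position, so the direction rests on size alone. The expectation is a number higher than that of compound 3, beyond the scatter, but well below that of compound 1.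

For compound 4 the estimate in this assay is 3 nM, within 0.6 nM to 15 nM, an expected step of a 15-fold higher number from compound 3 to compound 4 (1.18 log units; beyond the scatter).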

Compound 4, inhibition constant: 2.1 nM
For compound 4 the middle estimate is 1.4-fold (0.15 log units) above the measured one, and the stated range covers the measured number.
By their numbers in this assay, from the lowest: compound 3; then compounds 2 and 4 (each within the scatter of the next); then compound 1.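

In this assay a ring on this aromatic carbon is not needed for most of the gain over bromo: the open-chain pent-1-en-1-yl gives an 80-fold lower number from compound 1 to compound 4 (1.91 log units; beyond the scatter) and so joins the ring groups well below the bromo compound. Set against 4,4-difluorocyclohexyl, the same chain gives a 1.4-fold higher number from compound 2 to compound 4 (0.15 log units; within the scatter) and the two compounds cannot be told apart on this read-out, so having a ring does not by itself separate these groups. 4-(tert-butyl)cyclohex-1-en-1-yl still stands apart, with an 11-fold higher number from compound 3 to compound 4 (1.02 log units; beyond the scatter) on its replacement, and since pent-1-en-1-yl also carries a double bond outside the aromatic rings, that double bond alone does not account for the low number of compound 3.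

Still open, on these data alone, is which feature of the compound 3 group matters, and how far the result depends on chain length or on the double bond; a saturated pentyl chain, a longer chain, plain cyclohexyl or an amine at this carbon would each bear on this. Nothing available here explains the differences among these groups.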